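The source may hold more compounds than are shown below. What is called first, only, known or untested is meant among the compounds shown, and "the series" means these compounds.

In a physicochemical assay for metabolic stability, read by HPLC and mass spectrometry, in phosphate buffer, at 37 degrees C, at pH 7.4 (a higher number here means that the compound lasts longer, a lower number that the compound disappears faster), compound 1 `CC(C)(O/N=C(\C(=O)N[C@@H]1C(=O)N(S(=O)(=O)O)[C@@H]1CNC(=O)CN)c1csc(N)n1)C(=O)O` gives 149 h, compound 2 `CC(C)(O/N=C(\C(=O)N[C@@H]1C(=O)N(S(=O)(=O)O)[C@@H]1CN1CCCCC1=O)c1csc(N)n1)C(=O)O` gives 214 h and compound 3 `CC(C)(O/N=C(\C(=O)N[C@@H]1C(=O)N(S(=O)(=O)O)[C@@H]1Cn1cnnc1)c1csc(N)n1)C(=O)O` gives 113 h. Compound 3 therefore stands within the scatter of both others, with a 1.3-fold lower number from compound 1 to compound 3 (0.12 log units; within the scatter) and a 1.9-fold lower number from compound 2 to compound 3 (0.28 log units; within the scatter). Compound 4 `CC(C)(O/N=C(\C(=O)N[C@@H]1C(=O)N(S(=O)(=O)O)[C@@H]1Cn1cc(CO)nn1)c1csc(N)n1)C(=O)O` differs from compound 3 by one exchange: 4-(hydroxymethyl)-1H-1,2,3-triazol-1-yl in place of 4H-1,2,4-triazol-4-yl on a saturated chain carbon bound to a saturated ring carbon. Among the compounds with values here, no measured step covers this exchange itself. Within the data shown here, the steps that bear on it are the other exchanges at the same place, those above and a 1.4-fold higher number from compound 1 to compound 2 (0.16 log units; within the scatter), and none of them leaves the scatter. No step beyond the scatter is therefore expected in this assay, and no direction can be told. The expected step is a 1.2-fold higher number from compound 3 to compound 4 (0.06 log units; within the scatter). Compound 4 is estimated at 130 h, with an expected range from 70 h to 250 h.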

Compound 4, half-life: > 37 h
Compound 4 was reported as a limit; the forecaster's own chance of this, stated with the estimate: 5%; the middle value is on the limit's open side.
By their numbers in this assay, from the lowest: compounds 3, 1 and 2 (each within the scatter of the next).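

In this assay, within the data shown here, compound 4 gives > 37 h, which is a limit and not a number, so no step to it from compound 1, compound 2 or compound 3 can be read. The compounds shown leave open how the half-life of compound 4 compares with theirs.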